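The source may hold more compounds than are shown below. What is called first, only, known or untested is meant among the compounds shown, and "the series" means these compounds.

Working notes on the series, read in a functional assay on PC-3 cells (Homo sapiens) for cytotoxicity, read by MTT assay; on this read-out higher numbers stand for weaker inhibition and lower numbers for stronger inhibition. Compound 1 `COc1ccc2cc([C@H](C)c3nnc(SCc4ccc(Cl)cc4)n3-c3ccc(Cl)cc3)ccc2c1` gives 5800 nM, compound 2 `COc1ccc2cc([C@H](C)c3nnc(SCc4ccc(F)cc4)n3-c3ccc(Cl)cc3)ccc2c1` gives 10800 nM, and compound 3 `COc1ccc2cc([C@H](C)c3nnc(SCc4ccccc4)n3-c3ccc(Cl)cc3)ccc2c1` gives 14200 nM. Compound 3 therefore stands within the scatter of compound 2, and its number is higher than that of compound 1 by a modest margin.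

Compound 4 `COc1ccc2cc([C@H](C)c3nnc(SCc4ccc(C)cc4)n3-c3ccc(Cl)cc3)ccc2c1` has methyl in place of hydrogen on an aromatic carbon, para to a large group: methyl in place of hydrogen on an aromatic carbon. The same place carries the changes already measured. Hydrogen for chloro gives a 2.4-fold higher number from compound 1 to compound 3 (0.39 log units; beyond the scatter), the only step here beyond the scatter. Hydrogen for fluoro gives a 1.3-fold higher number from compound 2 to compound 3 (0.12 log units; within the scatter), and fluoro for chloro gives a 1.9-fold higher number from compound 1 to compound 2 (0.27 log units; within the scatter). No methyl has been measured at this place, so these steps give only an indirect guide.

A small move towards a lower number is expected, probably not beyond the scatter. The expected step is a 1.6-fold lower number from compound 3 to compound 4 (0.20 log units; within the scatter). For compound 4 the estimated value is 9000 nM, with an expected range of 4500 nM to 18000 nM.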

Compound 4, half-maximal inhibitory concentration: 8400 nM
Compound 4: the middle estimate sits 1.1-fold (0.03 log units) above what was measured; the measured number falls inside the stated range.
By their numbers in this assay, from the lowest: compounds 1, 4, 2 and 3 (each within the scatter of the next, the first and the last beyond it).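

Methyl is the first carbon group read at this place on the benzyl ring, and it gives a 1.7-fold lower number from compound 3 to compound 4 (0.23 log units; within the scatter), so it cannot be separated from hydrogen here. It also stands close to both halogens, with a 1.3-fold lower number from compound 2 to compound 4 (0.11 log units; within the scatter) and a 1.4-fold higher number from compound 1 to compound 4 (0.16 log units; within the scatter), although compound 1 and compound 3 lie beyond the scatter of each other. No measurement at hand accounts for these small steps.

Still open, on these data alone, is how a methoxy, trifluoromethyl, amine or carboxylic acid group would read at this place, and whether a longer chain such as ethyl would stay as close to hydrogen as methyl does. Also open, as far as these compounds go, is whether these steps would hold if another part of the shared core were changed.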